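Furoxan-linked hydroxamates: chain change from compound 1 to compound 3

A few compounds are considered here, and "the series" means these few. Any claim that something is new, unique, unknown or untested is made for them only; others in the source may bear on it.

Compound 1 `O=C(CCCOc1no[n+]([O-])c1S(=O)(=O)c1ccccc1)NO` is the reference point of the pair measured so far. In a functional assay on ES2 cells (Homo sapiens) for inhibition, read by MTT assay, with a stated time of 48 h (on this read-out higher numbers stand for weaker inhibition and lower numbers for stronger inhibition), compound 1 gives 3780 nM, the lowest of the two numbers, while its neighbour compound 2 `O=C(/C=C/COc1no[n+]([O-])c1S(=O)(=O)c1ccccc1)NO` gives 19100 nM. Among the measured compounds shown here, the only measured step is a 5.1-fold higher number from compound 1 to compound 2 (0.70 log units; beyond the scatter), a change on the same chain that carries the hydroxamate.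

Compound 3 `O=C(NO)OCCOCCOc1no[n+]([O-])c1S(=O)(=O)c1ccccc1` differs from compound 1 thus: 2-((hydroxycarbamoyl)oxy)ethoxy in place of (hydroxycarbamoyl)methyl on a saturated chain carbon, two bonds along the chain from an oxygen on an aromatic ring. For the measured compounds named here, no measured pair covers this change directly; the step from compound 1 to compound 2 shows only that altering this chain can move the number beyond the scatter, in the weaker direction. The carbamate-for-hydroxamate exchange and the lengthened linker are unmeasured here.

For compound 3 the expected step is a 3.2-fold higher number from compound 1 to compound 3 (0.50 log units; beyond the scatter), a modest weakening in this assay. Compound 3 is therefore estimated at 12000 nM, with a range from 4000 nM to 40000 nM.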

Compound 3, half-maximal inhibitory concentration: 18100 nM
Compound 3: middle estimate off by 1.5-fold (0.18 log units), on the low side; low and high end bracket the measured number.
By their numbers in this assay, from the lowest: compound 1; then compounds 3 and 2 (each within the scatter of the next).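

In this assay, 2-((hydroxycarbamoyl)oxy)ethoxy in place of (hydroxycarbamoyl)methyl on a saturated chain carbon, two bonds along the chain from an oxygen on an aromatic ring, gives a 4.8-fold higher number from compound 1 to compound 3 (0.68 log units; beyond the scatter) on this read-out. This is a second change on the chain that leaves the number higher beyond the scatter, so compound 1 stays the lowest of the three, though the new end group and the longer linker change together in this one step and cannot be told apart. No evidence at hand accounts for the weakening.

Still open, from the compounds shown here alone, is how a longer saturated chain ending in the same hydroxamate would compare with compound 1. Also open, going by these compounds, is whether a carboxylic acid at the chain end would keep any inhibition on this core.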